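This account rests on a few compounds, and the source may have more. Where it says the series, first, only, none or still open, it means among the compounds named here.

Measured in a functional assay on LoVo cells (Homo sapiens) for inhibition, read by MTT assay, with a stated time of 48 h; a higher number here means a weaker inhibitor, a lower number a stronger inhibitor:
- Compound 1 `COc1ccc(N(C)c2nc(C)nc3ccccc23)cc1C(=O)OCCC[Se]C#N`: 854 nM
- Compound 2 `COc1ccc(N(C)c2nc(C)nc3ccccc23)cc1C(=O)NCC[Se]C#N`: 561 nM
- Compound 3 `COc1ccc(N(C)c2nc(C)nc3ccccc23)cc1OCC[Se]C#N`: 19 nM

Of these three, compound 3 has the lowest number (19 nM), which makes it the strongest inhibitor of the set. The next compound, compound 4 `COc1ccc(N(C)c2nc(C)nc3ccccc23)cc1`, keeps the shared core but loses the side chain of compound 3: a hydrogen atom in place of a group of 6 heavy atoms (3 carbon, 1 nitrogen, 1 oxygen, 1 selenium; no ring), on an aromatic carbon.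

Among the compounds with values here, three measured steps bear on this change, though none of them removes the side chain completely. The first, a 1.5-fold lower number from compound 1 to compound 2 (0.18 log units; within the scatter), is small. The other two are large: a 45-fold lower number from compound 1 to compound 3 (1.65 log units; beyond the scatter) and a 30-fold lower number from compound 2 to compound 3 (1.47 log units; beyond the scatter). So among these compounds, the group of 6 heavy atoms goes with the lowest number, and no compound here goes against that. Within the data shown here, still, three compounds make a thin trend, and no measured compound lacks the group, so extending it to a bare hydrogen is a guess.

The direction of a 30-fold lower number from compound 2 to compound 3 (1.47 log units; beyond the scatter) suggests a further fall, but a much smaller one is expected, since compound 3 is already low. The expected change is a 2.4-fold lower number from compound 3 to compound 4 (0.38 log units; beyond the scatter), and it could prove to be no real change at all. For compound 4 the estimated value is 8 nM, with an expected range from 1.5 nM to 50 nM.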

Compound 4, half-maximal inhibitory concentration: 8 nM
For compound 4 middle estimate and measured number coincide at the digits printed; the range from low to high includes it.
By their numbers in this assay, from the lowest: compound 4; then compound 3; then compounds 2 and 1 (each within the scatter of the next).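

Compounds 1, 2 and 3 all carry a selenium-containing chain on this aromatic carbon, so they could not show what happens with no chain at all; in this assay, replacing the group of 6 heavy atoms with a hydrogen atom still lowers the number (a 2.4-fold lower number from compound 3 to compound 4 (0.38 log units; beyond the scatter)), which makes compound 4 the strongest inhibitor of the four. The selenium-containing chain is therefore not required for strong inhibition in this set, and the longer ester and amide groups sit much further from the bare core (a 70-fold lower number from compound 2 to compound 4 (1.85 log units; beyond the scatter) and a 110-fold lower number from compound 1 to compound 4 (2.03 log units; beyond the scatter)), so in these compounds every added group goes with a higher number and none goes against that. No measurement shown here explains why the number changes at this position.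

Going by these compounds, it remains open whether a small group on this carbon, such as a hydroxyl, an amine or a plain ethoxy chain, would match the hydrogen atom or exceed it. Also open, on these data alone, is which part of the group of compound 3 matters, the selenium or the nitrile, which a sulfur-containing chain or a chain ending in a carboxylic acid could begin to separate.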